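The source may hold more compounds than are shown below. What is called first, only, known or untested is meant among the compounds shown, and "the series" means these compounds.

Compound 3 `CC(=O)OCCOCN1c2ccccc2C(=O)N(Cc2ccccc2)S1(=O)=O` gives 50 ug/mL in a functional assay on HEL cells (Homo sapiens) for cytotoxicity; a higher number here means that more compound is tolerated, a lower number that less compound is tolerated. It stands level with compound 1 `O=C1c2ccccc2NS(=O)(=O)N1Cc1ccccc1`, which gives 50 ug/mL; the step of no change at the digits printed from compound 1 to compound 3 (within the scatter) shows that adding the (2-acetoxyethoxy)methyl group on the sulfonamide nitrogen in the ring left the read-out unchanged. Compound 2 `C#CCOCN1C(=O)c2ccccc2NS1(=O)=O` gives > 50 ug/mL, which is a limit of the assay rather than a number. The step of a number no lower from compound 1 to compound 2 (the limit leaves the size open) is therefore of unreadable size, and one of the three values sits at that limit (the limit of > 50 ug/mL in this assay, at which 1 of the 3 values shown sits).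

Compound 4 `O=C(OCCOCN1c2ccccc2C(=O)N(Cc2ccccc2)S1(=O)=O)c1ccccc1` differs from compound 3 by phenyl in place of methyl on a carbonyl carbon, so that the acetyl becomes a benzoyl. Neither measured step covers this kind of change: one is flat, the other is open. With compound 3 and compound 1 level and nothing pointing either way, the step of no change at the digits printed from compound 3 to compound 4 (within the scatter) is expected to stay within the scatter. Compound 4 is estimated to give 50 ug/mL in this assay, with a range from 25 ug/mL to 100 ug/mL.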

Compound 4, minimum cytotoxic concentration: 50 ug/mL
Estimate against measurement, compound 4: no gap at the digits printed; low and high end bracket the measured number.
By their numbers in this assay, from the lowest: compounds 1, 3 and 4 (each within the scatter of the next).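

Replacing methyl by phenyl on the carbonyl carbon, which turns acetyl into benzoyl, gave no change at the digits printed from compound 3 to compound 4 (within the scatter) in this assay. Going by these compounds alone, this is the first measured step at this carbonyl carbon; the earlier steps concerned the sulfonamide nitrogen in the ring and the saturated chain carbon bound to an amide-type nitrogen. In this one pair, a group of 6 heavy atoms with a six-membered aromatic ring took the place of a group of 1 heavy atom, and the read-out stayed within the scatter.

On these data alone, whether an amine or a carboxylic acid on the benzoyl, or a longer chain in place of the acetoxy or benzoyloxy ester, would leave the read-out equally flat stays open. Compound 2 remains a limit and not a number, so the step to it cannot be read: the limit of > 50 ug/mL in this assay, at which 1 of the 4 values shown sits.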